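A few compounds are considered here, and "the series" means these few. Any claim that something is new, unique, unknown or untested is made for them only; others in the source may bear on it.

Compound 2 `O=C(/C=C/c1cccnc1)Nc1ccc2ncnc(Nc3cccc(Cl)c3)c2c1` was tested in a functional assay on A549 cells (Homo sapiens) for antiproliferative activity, read by MTT assay, with a stated time of 48 h (on this read-out lower numbers stand for stronger inhibition and higher numbers for weaker inhibition), where compound 2 gives 4320 nM. Compound 1 `Clc1cccc(Nc2ncnc3ccc(NCc4cccc(Br)n4)cc23)c1` gives 2950 nM in this assay, a value within the scatter of compound 2, so the two cannot be told apart on these numbers. Compound 3 `O=C(/C=C/c1c[nH]c2ccccc12)Nc1ccc2ncnc(Nc3cccc(Cl)c3)c2c1` has not yet been measured; it differs from compound 2 by 1H-indol-3-yl in place of pyridin-3-yl on a double-bonded chain carbon bound to a double-bonded chain carbon. Going by the values given here, no measured pair shows a step of this kind. Compound 3 is therefore expected to stay near this level, an estimated step of a 1.2-fold lower number from compound 2 to compound 3 (0.09 log units; within the scatter) that need not exceed the scatter. The estimate for compound 3 is 3500 nM, with a range from 1200 nM to 10000 nM.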

Compound 3, half-maximal inhibitory concentration: 3670 nM
Compound 3: the middle estimate sits 1.0-fold (0.02 log units) below what was measured; low and high end bracket the measured number.
By their numbers in this assay, from the lowest: compounds 1, 3 and 2 (each within the scatter of the next).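

In this assay, the swap at this position gives a 1.2-fold lower number from compound 2 to compound 3 (0.07 log units; within the scatter), the first step seen on a double-bonded chain carbon bound to a double-bonded chain carbon. The place therefore accepts 1H-indol-3-yl, with its added ring and a hydrogen-bond donor instead of an acceptor, without a change that can be told from the scatter. No evidence is available to explain this result.

The compounds shown leave open whether an aliphatic amine or a carboxylic acid at this place would move the number beyond the scatter. They also leave open how an unsubstituted phenyl ring would compare with pyridin-3-yl.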